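This account rests on a few compounds, and the source may have more. Where it says the series, first, only, none or still open, it means among the compounds named here.

Measured compounds:
- compound 1 `O=c1ccn([C@@H]2O[C@H](COP(=O)(O)OP(=O)(O)OP(=O)(O)OP(=O)(O)Oc3cccc([N+](=O)[O-])c3)[C@@H](O)[C@H]2O)c(=O)[nH]1` gives 3330 nM
- compound 2 `O=c1[nH]/c(=N\OCc2ccccc2)ccn1[C@@H]1O[C@H](COP(=O)(O)OP(=O)(O)OP(=O)(O)OP(=O)(O)O[C@H]2O[C@H](CO)[C@@H](O)[C@H](F)[C@H]2O)[C@@H](O)[C@H]1O` gives 2640 nM
- compound 3 `O=c1[nH]/c(=N\OCc2ccccc2)ccn1[C@@H]1O[C@H](COP(=O)(O)OP(=O)(O)OP(=O)(O)O)[C@@H](O)[C@H]1O` gives 620 nM

These three compounds were tested in an in vitro functional assay on 1321-N1 cells for agonist activity at P2Y purinoceptor 2 (Homo sapiens), read by scintillation proximity assay and inositol phosphate accumulation, with a stated time of 30 min; a higher number here means that more compound is needed for the effect, a lower number that less compound is needed. Compound 3 stands lowest of the three numbers, so it needs the least compound for the effect. Its nearest neighbour is compound 2, whose number is higher by a step beyond the scatter, and compound 1 lies further still, also beyond the scatter. Compound 3 is therefore the most potent of the three measured compounds.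

Compound 4 `CC(C)(C)O/N=c1/ccn([C@@H]2O[C@H](COP(=O)(O)OP(=O)(O)OP(=O)(O)O)[C@@H](O)[C@H]2O)c(=O)[nH]1` has not yet been measured. It differs from compound 3 in one place: tert-butyl in place of benzyl on an oxygen. The rest of the shared core stays as it is in compound 3.

Among the compounds with values here, no pair of measured compounds differs in only this one place, so there is no measured step to lean on for the size or direction of this change. The expectation is a small step from compound 3 to compound 4 in this assay, either none beyond the scatter or a slight rise in the number, as a 1.6-fold higher number from compound 3 to compound 4 (0.21 log units; within the scatter). Compound 4 is therefore estimated at 1000 nM, with a range from 300 nM to 4000 nM.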

Compound 4, half-maximal effective concentration: 1500 nM
Compound 4: the middle estimate sits 1.5-fold (0.18 log units) below what was measured; the range from low to high includes it.
By their numbers in this assay, from the lowest: compound 3; then compounds 4, 2 and 1 (each within the scatter of the next, the first and the last beyond it).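

Replacing benzyl with tert-butyl on the oxygen attached to the double-bonded nitrogen gives a 2.4-fold higher number from compound 3 to compound 4 (0.38 log units; beyond the scatter) in this assay and provides the first measured view of how this place responds to a change. The step is modest but real, so the group on this oxygen does affect how much compound is needed. The aromatic ring of benzyl is not required for a measurable effect, as compound 4 has no ring in this group and still gives 1500 nM in this assay, although compound 3 needs less. No measured evidence here explains this step.

With only benzyl and tert-butyl to compare, the loss of the ring cannot be separated from the change to a shorter, branched group, and a cyclohexylmethyl, phenethyl or simple methyl group on the same oxygen would help to tell these apart. As far as these compounds go, it also remains open whether this exchange would give a step of similar size in a compound with a longer phosphate chain and a sugar at its end, such as compound 2.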